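The source may report more compounds than this note shows. Statements on the series, on what has been measured and on what is new or still open speak of the compounds shown alone.

Measured so far in a functional assay on NB-4 cells (Homo sapiens) for inhibition, with a stated time of 72 h; on this read-out lower numbers stand for stronger inhibition and higher numbers for weaker inhibition:

- Compound 1 `NNC(=O)/C=C/c1ccc(-c2ccccc2)cc1`: 7100 nM
- Compound 2 `CC(=O)SCC(=O)/C=C/c1ccc(-c2ccccc2)cc1`: > 20000 nM (a limit, not a number)

On these data alone, compound 2 stands on (the limit of > 20000 nM in this assay, at which 1 of the 2 values shown sits), so its true number is unknown. Compound 3 `N#CSC/C=C/c1ccc(-c2ccccc2)cc1` brings this change: (cyanosulfanyl)methyl in place of ((acetylsulfanyl)methyl)carbonyl on a double-bonded chain carbon bound to a double-bonded chain carbon. Among the measured compounds shown here, the one measured step, an at least 2.8-fold higher number from compound 1 to compound 2 (0.44 log units; beyond the scatter), altered the group on a carbonyl carbon and went beyond the scatter, so a change of this kind can move the number. A modest move to a lower number in this assay is expected, though the limit leaves its size open. The estimated step is an at least 1.8-fold lower number from compound 2 to compound 3 (0.25 log units; that floor lies within the scatter). Compound 3 is expected near 11000 nM, with an estimated range from 4000 nM to 20000 nM.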

Compound 3, half-maximal inhibitory concentration: > 20000 nM
Compound 3 was reported as a limit (the forecaster's own chance of this, stated with the estimate: 30%); middle value at least 1.8-fold (0.25 log units) from the limit.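

In this assay compound 3 also gives only a limit, > 20000 nM, not a number. Replacing aminocarbamoyl with (cyanosulfanyl)methyl on a double-bonded chain carbon bound to a double-bonded chain carbon gives an at least 2.8-fold higher number from compound 1 to compound 3 (0.44 log units; beyond the scatter), so a second, different replacement of that group also raises the number. The step between compound 2 and compound 3 cannot be read, because both stand on the limit: the limit of > 20000 nM in this assay, at which 2 of the 3 values shown sit.

On these data alone, what a carboxylic acid or an amine at this place would give stays open. So do the true values of compound 2 and compound 3.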